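The compounds below may be only part of what the source reports. "The series", "measured", "known", "first", "only" and "open" are said of these compounds alone.

Working notes on the series. Compound 1 `Cn1ncc(Cl)c1-c1cc(C(=O)N[C@@H]2CN[C@H](CC(O)CO)C[C@H]2c2ccc(F)c(F)c2)oc1Cl` gives 800 nM in a functional assay on HCT-116 cells (Homo sapiens) for antiproliferative activity, read by sulforhodamine B assay, with a stated time of 72 h; on this read-out higher numbers stand for weaker inhibition and lower numbers for stronger inhibition. Among the compounds with values here, compound 3 `CC(=O)OCC[C@@H]1C[C@@H](c2ccc(F)c(F)c2)[C@H](NC(=O)c2cc(-c3c(Cl)cnn3C)c(Cl)o2)CN1` gives 690 nM in this assay; the step of a 1.2-fold lower number from compound 1 to compound 3 (0.06 log units; within the scatter) is the only measured change at the side chain on the saturated ring carbon, and it did not move the number beyond the scatter. Compound 2 `Cn1ncc(Cl)c1-c1cc(C(=O)N[C@@H]2CN[C@H](CCn3cncn3)C[C@H]2c2ccc(Cl)c(Cl)c2)oc1Cl` gives 560 nM in this assay, the lowest of the three numbers shown, though its gaps to compound 3 and to compound 1 are both within the scatter, so no order among the three can be claimed.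

Compound 4 `Cn1ncc(Cl)c1-c1cc(C(=O)N[C@@H]2CN[C@H](CC(=O)NC3CCC3)C[C@H]2c2ccc(Cl)c(Cl)c2)oc1Cl` differs from compound 2 by cyclobutylcarbamoyl in place of (1H-1,2,4-triazol-1-yl)methyl on a saturated chain carbon bound to a saturated ring carbon. The shared core and the rest of the molecule are untouched. Within the data shown here, the one measured step at this position, a 1.2-fold lower number from compound 1 to compound 3 (0.06 log units; within the scatter), bears on it only loosely, since it swaps different groups on a different pair, but it shows that a change of the chain here left the number essentially unchanged. Among the measured compounds shown here, no measured step speaks for a large move in either direction, so the expectation for compound 4 is a step of about a 1.0-fold lower number from compound 2 to compound 4 (0.01 log units; within the scatter), that is, nothing beyond the scatter. Compound 4 is therefore estimated at 550 nM in this assay, with a range of 200 nM to 1600 nM.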

Compound 4, half-maximal inhibitory concentration: 430 nM
Compound 4: middle estimate off by 1.3-fold (0.11 log units), on the high side; measured number inside the range.
By their numbers in this assay, from the lowest: compounds 4, 2, 3 and 1 (each within the scatter of the next).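

In this assay, the new pair gives a 1.3-fold lower number from compound 2 to compound 4 (0.11 log units; within the scatter), so a second exchange on a saturated chain carbon bound to a saturated ring carbon, on a different pair of compounds, also stays inside the scatter. This exchange is a larger one than the earlier step at this place: a five-membered aromatic ring with hetero atoms gives way to a four-membered non-aromatic ring of carbon only, and an amide carbonyl and a hydrogen-bond donor enter, yet the number does not leave the scatter. No measurement available here explains why the number holds through this exchange.

Whether a primary amine or a carboxylic acid at the end of this chain, or a longer chain, would give a number beyond the scatter remains open, as the four compounds shown give no step of that size at this place. The halogens on the aryl ring also remain unresolved, since compounds with the two halogen patterns differ at the side chain as well, so the contribution of that ring to the number cannot be separated from that of the chain.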